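This account rests on a few compounds, and the source may have more. Where it says the series, first, only, none or still open, it means among the compounds named here.

Compound 1 `CC(C#CCn1ccnc1)N1CCCC1=O` and compound 2 `CC(C#CCN(C)C)N1CCCC1=O` share one core and differ in a single place: dimethylamino in place of 1H-imidazol-1-yl on a saturated chain carbon bound to a triple-bonded carbon. In a functional assay on the whole organism for agonist activity, with Mus musculus as the target (a lower number here means that less compound is needed, a higher number that more compound is needed for the effect), compound 1 gives only a limit, > 100 mg/kg, not a number. In this assay compound 2 gives 100 mg/kg. The step of a number no higher from compound 1 to compound 2 (the limit leaves the size open) leaves its size open because of the limit of > 100 mg/kg in this assay, at which 1 of the 3 values shown sits.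

Compound 3 `CN1CCN(CC#CCn2ccnc2)C1=O` is built on a different core; the difference between the two cores is not broken down here. In this assay compound 3 gives 0.97 mg/kg, a value far from that of compound 2, beyond the usual scatter.

Compound 4 `CN(C)CC#CCN1CCN(C)C1=O`, not yet measured, stands to compound 3 as compound 2 stands to compound 1: dimethylamino in place of 1H-imidazol-1-yl on a saturated chain carbon bound to a triple-bonded carbon. The same kind of change is repeated on another core. The earlier step reads as no higher, with the size unknown, so the expectation for compound 4 rests on compound 3 and its value 0.97 mg/kg. The estimated step of a 1.5-fold higher number from compound 3 to compound 4 (0.19 log units; within the scatter) is expected to be small. In this assay compound 4 is expected to give about 1.5 mg/kg.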

Compound 4, dose for half-maximal effect: 0.37 mg/kg
Compound 4: middle estimate off by 4.1-fold (0.61 log units), on the high side, within the range that was stated.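

On the core of compound 3, dimethylamino in place of 1H-imidazol-1-yl gives a 2.6-fold lower number from compound 3 to compound 4 (0.42 log units; beyond the scatter) in this assay on this core, so less compound is needed for the effect. Compound 1 gives only the limit > 100 mg/kg and no number, so the step on the other core cannot be read and the two steps cannot be compared in size: the same change on two cores in this assay, a number no higher (the limit leaves the size open) from compound 1 to compound 2 and a 2.6-fold lower number (0.42 log units; beyond the scatter) from compound 3 to compound 4; the limit leaves it open whether they differ. The two cores therefore show no rise in the number for this change, but they do not show that a step of the same size carries from one core to the other, and two cores are too few for a general rule.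

The compounds shown leave open whether other amines on the same chain, such as diethylamino or pyrrolidin-1-yl, would behave like dimethylamino on either core. They also leave open how a longer chain carrying dimethylamino would read in this assay on either core.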